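A few compounds are considered here, and "the series" means these few. Any claim that something is new, unique, unknown or untested is made for them only; others in the source may bear on it.

Compound 1 `Cc1ccc(S/C(=C/c2ccc(Br)cc2)C(=O)c2ccc(Cl)cc2)cc1` is a vinyl sulfide carrying a 4-methylphenyl on sulfur. In a functional assay on DU-145 cells (Homo sapiens) for inhibition, read by trypan blue exclusion, with a stated time of 96 h (on this read-out lower numbers stand for stronger inhibition of growth and higher numbers for weaker inhibition of growth), compound 1 gives 25000 nM, the second highest of three numbers. Compound 2 `Cc1ccc(S/C(=C/c2ccc(Oc3ccccc3)cc2)C(=O)c2ccc(Cl)cc2)cc1` gives 10000 nM, and a 2.5-fold lower number from compound 1 to compound 2 (0.40 log units; beyond the scatter). Compound 3 `Cc1ccc(S/C(=C/c2cc(C)cc(C)c2)C(=O)c2ccc(Cl)cc2)cc1` gives 50000 nM, and a 2.0-fold higher number from compound 1 to compound 3 (0.30 log units; within the scatter). Compound 4 `Cc1ccc(CS/C(=C/c2ccc(Br)cc2)C(=O)c2ccc(Cl)cc2)cc1` differs from compound 1 only at the sulfur: 4-methylbenzyl in place of 4-methylphenyl on a sulfur. Going by the values given here, neither measured step touches the sulfur substituent, so none bears directly on this change; both steps at other positions were modest or within the scatter, and no measured pair speaks to inserting a carbon between the sulfur and its aryl ring. Compound 4 is therefore expected to give 30000 nM, between 10000 nM and 100000 nM, which is expected to mean a 1.2-fold higher number from compound 1 to compound 4 (0.08 log units; within the scatter).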

Compound 4, concentration for 50% growth inhibition: 10000 nM
For compound 4 the middle estimate is 3.0-fold (0.48 log units) above the measured one, within the range that was stated.
By their numbers in this assay, from the lowest: compounds 2 and 4 (each within the scatter of the next); then compounds 1 and 3 (each within the scatter of the next).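

The sulfur substituent can be changed without losing activity: 4-methylbenzyl in place of 4-methylphenyl on a sulfur gives a 2.5-fold lower number from compound 1 to compound 4 (0.40 log units; beyond the scatter), a modest step toward stronger inhibition of growth. Going by these compounds alone, this is the first measured change at this position, and it shows that a group larger by one carbon is tolerated there. Nothing available explains this step.

On these data alone, it remains open whether a longer chain on the sulfur, such as 2-phenylethyl, would go further. As far as these compounds go, an amine on the ring of the 4-methylbenzyl group is equally open.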